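Flipping One Stereocentre in Compound 1

This account rests on a few compounds, and the source may have more. Where it says the series, first, only, none or still open, it means among the compounds named here.

Compound 1, `Cc1ccc(OC[C@@H]2CCN2)cn1`: 0.057 nM
Compound 2, `CCc1ccc(OC[C@@H]2CCN2)cn1`: 19 nM
Compound 3, `C=Cc1ccc(OC[C@@H]2CCN2)cn1`: 1.25 nM

These three compounds were measured in an assay on brain for binding affinity to Neuronal acetylcholine receptor; alpha4/beta2 (Rattus norvegicus), read by radioligand binding; on this read-out lower numbers stand for stronger inhibition and higher numbers for weaker inhibition. Compound 1 gives the lowest number of the three. Its nearest neighbour is reached by a 22-fold higher number from compound 1 to compound 3 (1.34 log units; beyond the scatter), its furthest by a 330-fold higher number from compound 1 to compound 2 (2.52 log units; beyond the scatter); between the other two lies a 15-fold lower number from compound 2 to compound 3 (1.18 log units; beyond the scatter). All three of these steps, large as they are, concern only the group attached to the aromatic carbon.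

Compound 4, `Cc1ccc(OC[C@H]2CCN2)cn1`, differs from compound 1 in a different way: the two compounds have the same atoms and bonds and differ only in configuration as drawn: 1 of 1 stereo elements differ; a stereocentre at a saturated ring carbon is drawn S in compound 1 and R in compound 4. Among the compounds with values here, no measured step touches a change in configuration, so the three steps above give no direct guide to its size, and the estimate is anchored only by the value of compound 1. With that caveat, compound 4 is expected to bind more weakly than compound 1, a step estimated as a 35-fold higher number from compound 1 to compound 4 (1.55 log units; beyond the scatter), but with wide uncertainty in both directions. Compound 4 is therefore estimated at about 2 nM, within a range from 0.1 nM to 50 nM.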

Compound 4, inhibition constant: 0.053 nM
Estimate against measurement, compound 4: 38-fold (1.58 log units) above; the whole stated range lies above it.
By their numbers in this assay, from the lowest: compounds 4 and 1 (each within the scatter of the next); then compound 3; then compound 2.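

Changing the stereocentre at the saturated ring carbon from S to R gives a 1.1-fold lower number from compound 1 to compound 4 (0.03 log units; within the scatter), so in this assay the drawn configuration at this position makes no measurable difference while methyl sits on the aromatic carbon. The earlier compounds shown here changed only the group on the aromatic carbon, and there even a small change moved the number far, as in a 330-fold higher number from compound 1 to compound 2 (2.52 log units; beyond the scatter); this series is therefore sensitive to that group, yet not to the configuration in this pair. The comparison is a clean one, since nothing else separates the two compounds: the fact that compounds 1 and 4 differ only in the configuration as drawn.

As far as these compounds go, whether the R and S forms would also match with ethyl or vinyl on the aromatic carbon stays open. So does the effect of an amine or a propyl chain at that same place.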